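A few compounds are considered here, and "the series" means these few. Any claim that something is new, unique, unknown or untested is made for them only; others in the source may bear on it.

Compound 1 `COCCOC1CCN(c2ccc(-c3cc(-c4cccc(Br)c4)c4c(N)ncnc4n3)nn2)CC1` gives 10 umol/kg in a functional assay (on this read-out higher numbers stand for an effect only at larger amounts of compound and lower numbers for an effect already at smaller amounts), the highest of the three numbers measured; compound 2 `Nc1ncnc2nc(-c3ccc(N4CC5CC4CO5)nc3)cc(-c3cccc(Br)c3)c12` gives 8 umol/kg and compound 3 `Nc1ncnc2nc(-c3ccc(N4CCC(COC5CCOCC5)CC4)nn3)cc(-c3cccc(Br)c3)c12` gives 5 umol/kg, both within the scatter of compound 1. Compound 4 `CCO[C@H]1CN(c2ccc(-c3cc(-c4cccc(Br)c4)c4c(N)ncnc4n3)nn2)C[C@H]1OCC` has not yet been measured and differs from compound 1 by 3,4-diethoxypyrrolidin-1-yl in place of 4-(2-methoxyethoxy)piperidin-1-yl on an aromatic carbon. Going by the values given here, the only measured step that touches this part of the molecule is a 2.0-fold lower number from compound 1 to compound 3 (0.30 log units; within the scatter), which changed the group on the saturated ring rather than the ring itself. Because a 2.0-fold lower number from compound 1 to compound 3 (0.30 log units; within the scatter) stayed within the scatter, compound 4 is expected to show no change at the digits printed from compound 1 to compound 4 (within the scatter), no step beyond the scatter. Compound 4 is therefore estimated at 10 umol/kg, in the range 3 umol/kg to 30 umol/kg in this assay.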

Compound 4, dose for half-maximal effect: 25 umol/kg
For compound 4 the middle estimate is 2.5-fold (0.40 log units) below the measured one, within the range that was stated.
By their numbers in this assay, from the lowest: compounds 3, 2 and 1 (each within the scatter of the next); then compound 4.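

In this assay, going by these compounds alone, replacing the whole saturated ring on this aromatic carbon gives the first step beyond the scatter, a 2.5-fold higher number from compound 1 to compound 4 (0.40 log units; beyond the scatter), whereas the earlier change to the group carried by the ring stayed within it. The two groups have the same atoms and the same counts of hydrogen-bond donors and acceptors, so at this position the result depends on how those atoms are joined. Nothing available bears on the reason for this step.

The compounds shown leave open whether the higher number goes with the five-membered ring, the two ethoxy groups or the defined stereocentres. From the compounds shown here alone, how a piperidine carrying an amine or a carboxylic acid would stand here also remains open.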